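A few compounds are considered here, and "the series" means these few. Any claim that something is new, unique, unknown or untested is made for them only; others in the source may bear on it.

Series notes. Compound 1 `CC#C[C@@H](CC(=O)O)c1ccc(OC[C@H]2COc3ccc(C)cc3O2)cc1` gives 120 nM in a functional assay on HEK293 cells for agonist activity at Free fatty acid receptor 1 (Homo sapiens), read by fluorescence and calcium flux, with a stated time of 10 min; on this read-out higher numbers stand for an effect only at larger amounts of compound and lower numbers for an effect already at smaller amounts; compound 2 `CC#C[C@@H](CC(=O)O)c1ccc(OC[C@H]2COc3ccc(OC(F)(F)F)cc3O2)cc1` gives 700 nM; compound 3 `CC#C[C@@H](CC(=O)O)c1ccc(OC[C@H]2COc3ccc(C#N)cc3O2)cc1` gives 2100 nM, the highest number of the three, with a 3.0-fold higher number from compound 2 to compound 3 (0.48 log units; beyond the scatter) and an 18-fold higher number from compound 1 to compound 3 (1.24 log units; beyond the scatter). Compound 4 `CC#C[C@@H](CC(=O)O)c1ccc(OC[C@H]2COc3ccc(CO)cc3O2)cc1` differs from compound 3 in one place: hydroxymethyl in place of cyano on an aromatic carbon. Among the measured compounds shown here, no measured step exchanges a cyano for a hydroxymethyl. For the measured compounds named here, the steps that bear on the cyano itself are an 18-fold higher number from compound 1 to compound 3 (1.24 log units; beyond the scatter) and a 3.0-fold higher number from compound 2 to compound 3 (0.48 log units; beyond the scatter), both toward higher numbers, so compound 3 sits at the weak end of the set. For compound 4 the step is expected to be a 2.6-fold lower number from compound 3 to compound 4 (0.42 log units; beyond the scatter), back toward the numbers seen for compound 1 and compound 2. Compound 4 is therefore estimated at 800 nM, within 250 nM to 2500 nM.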

Compound 4, half-maximal effective concentration: > 30000 nM
Compound 4 ended at the assay's limit; the forecaster's own chance of this, stated with the estimate: 5%; middle value at least 37-fold (1.57 log units) away from the limit.
By their numbers in this assay, from the lowest: compound 1; then compound 2; then compound 3. At a limit, above all of these: compound 4.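

Compound 4 carries a limit of the assay, not a number: the limit of > 30000 nM in this assay, at which 1 of the 4 values shown sits. At this aromatic carbon, methyl, trifluoromethoxy and cyano all give measurable numbers, whereas hydroxymethyl, which brings a hydrogen-bond donor in place of cyano, gives an at least 14-fold higher number from compound 3 to compound 4 (1.15 log units; beyond the scatter), with an at least 42-fold higher number from compound 2 to compound 4 (1.63 log units; beyond the scatter) and an at least 250-fold higher number from compound 1 to compound 4 (2.39 log units; beyond the scatter) as the matching steps. A two-heavy-atom exchange at this position can therefore take the series to the limit.

The compounds shown leave open whether the hydroxyl hydrogen itself drives this step. A methoxymethyl or an aminomethyl on the same carbon would test that.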